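The source may report more compounds than this note shows. Statements on the series, on what has been measured and on what is new or still open speak of the compounds shown alone.

Of the compounds shown here, two of the shared core have been measured in a functional assay on L1210 cells (Mus musculus) for cytotoxicity, with a stated time of 48 h; a lower number here means a stronger inhibitor, a higher number a weaker inhibitor. Compound 1 `Clc1ccc(Cc2nn3c(Br)c(-c4ccc(Cl)cc4)nc3s2)cc1` sits at a limit of the assay, giving > 250000 nM, and reports no number. For the measured compounds named here, compound 2 `COc1ccc(-c2nc3sc(Cc4ccc(Cl)cc4)nn3c2Br)cc1` is the only compound with a number: in this assay compound 2 gives 63000 nM. Going by the values given here, the one measured step, an at least 3.9-fold lower number from compound 1 to compound 2 (0.59 log units; beyond the scatter), is the sole comparison on record, and its size is bounded only on one side because of the limit of > 250000 nM in this assay, at which 1 of the 2 values shown sits.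

Compound 3 `Cc1ccc(-c2nc3sc(Cc4ccc(Cl)cc4)nn3c2Br)cc1` differs from compound 2 in one place: methyl in place of methoxy on an aromatic carbon. The measured step from compound 1 to compound 2 concerns the same position but a different pair of groups, chloro and methoxy, so it bears on the new step only loosely. Among the compounds with values here, with no step of the methyl-for-methoxy kind measured, the expectation is drawn wide.

For compound 3 the step of a 1.7-fold higher number from compound 2 to compound 3 (0.24 log units; within the scatter) is expected to run toward a higher number, though possibly not beyond the scatter. In this assay compound 3 is therefore estimated at 110000 nM, within a range from 35000 nM to 250000 nM, with a fair chance that only a limit is returned.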

Compound 3, half-maximal inhibitory concentration: > 250000 nM
Compound 3 ended at the assay's limit; the forecaster's own chance of this, stated with the estimate: 35%; middle value at least 2.2-fold (0.35 log units) from the limit.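

In this assay, methyl in place of methoxy gives an at least 3.9-fold higher number from compound 2 to compound 3 (0.59 log units; beyond the scatter), so the gain seen on going from chloro to methoxy on this aromatic carbon now has a second comparison behind it. Compound 3 sits at a limit, > 250000 nM, which is not a number. Among the three groups at this position, only methoxy gives a readable value, while the step between compound 1 and compound 3 cannot be read, leaving chloro and methyl unordered: the limit of > 250000 nM in this assay, at which 2 of the 3 values shown sit.

On these data alone, how far the methyl and chloro compounds lie from compound 2 stays open, and every step at this position remains bounded on one side only, with compound 2 itself still weak at 63000 nM. Also open, as far as these compounds go, is whether the difference goes with the oxygen of methoxy or with the group as a whole, and whether a hydroxyl, an ethoxy or an amine on the same carbon would give a number in this assay, and how it would compare with that of compound 2.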